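Methoxy for methyl on a series that shows no cytotoxicity

The compounds below may be only part of what the source reports. "The series", "measured", "known", "first", "only" and "open" are said of these compounds alone.

Measured compounds and values:
compound 1, `Cc1ccc2[nH]c(=O)c(-c3nc4cc([N+](=O)[O-])ccc4[nH]3)cc2c1` — in an ADME assay on L02 cells (Homo sapiens) for cytotoxicity, read by MTT assay, with a stated time of 48 h (a higher number here means a weaker inhibitor, a lower number a stronger inhibitor), compound 1 gives > 100000 nM
compound 2, `Cc1ccc2[nH]c(=O)c(-c3nc4ccccc4[nH]3)cc2c1` — compound 2 gives > 100000 nM
compound 3, `Cc1ccc2[nH]c(=O)c(-c3nc4cc(Cl)ccc4[nH]3)cc2c1` — compound 3 gives > 100000 nM

Compound 1 stands only at a limit in this assay: the value > 100000 nM is a limit, not a number. The same holds for compound 2, whose > 100000 nM is a limit. Compound 3 likewise returns a limit, > 100000 nM. Consequently the steps between them cannot be read: a step that the two limits leave unreadable from compound 1 to compound 2, a step that the two limits leave unreadable from compound 1 to compound 3 and a step that the two limits leave unreadable from compound 2 to compound 3 all remain of unknown size, because every value sits at the limit of > 100000 nM in this assay, at which 3 of the 3 values shown sit.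

The compound not yet measured is compound 4, `COc1ccc2[nH]c(=O)c(-c3nc4cc([N+](=O)[O-])ccc4[nH]3)cc2c1`. It differs from compound 1 in one place: methoxy in place of methyl on an aromatic carbon. No measured step touches this position, so the three unreadable steps give no direction for it; they only show that the shared core, with nitro, hydrogen or chloro on the other ring, has shown no readable cytotoxicity at all in this assay.

Compound 4 is therefore expected to sit at the same limit, with an estimated value of 150000 nM (range 60000 nM to 400000 nM), and the step that the limit leaves unreadable from compound 1 to compound 4 is expected to be none beyond the scatter.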

Compound 4, half-maximal inhibitory concentration: > 100000 nM
Compound 4 gave a limit, no number (the forecaster's own chance of this, stated with the estimate: 85%); the middle value lies beyond the limit too.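

Compound 4, like compound 1, returns only a limit in this assay, so the step of methoxy in place of methyl between these two compounds cannot be read: the limit of > 100000 nM in this assay, at which 4 of the 4 values shown sit.

The compounds shown leave open whether methoxy in place of methyl changes cytotoxicity at all, and how far any of the four compounds lies beyond that limit.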